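A few compounds are considered here, and "the series" means these few. Any claim that something is new, unique, unknown or untested is made for them only; others in the source may bear on it.

Measured compounds in an ADME assay on microsomes from liver (Mus musculus) for metabolic stability, read by LC-MS, with a stated time of 30 min, tested at 1 uM; on this read-out higher numbers stand for a more stable compound and lower numbers for a less stable compound:
- compound 1 `O=C(NCc1ccc(S(=O)(=O)N2CCCCC2)cc1)c1cc2cnccc2s1` gives "below limit of detection" (no number reported).
- compound 2 `O=C(NCc1ccc(S(=O)(=O)N2CCCCC2)cc1)c1cc2ccncc2[nH]1` gives "below limit of detection" (no number reported).
- compound 3 `O=C(NCc1ccc(S(=O)(=O)N2CCCCC2)cc1)c1cnc2nccn2c1` gives 0.28%.

All three share a common core. For the measured compounds named here, compound 3 therefore stands as the only compound with a number, and that number is very low in this assay. Compound 4 `O=C(NCc1ccc(S(=O)(=O)c2cccc(C(F)(F)F)c2)cc1)c1cnc2nccn2c1` differs from compound 3 by 3-(trifluoromethyl)phenyl in place of piperidin-1-yl on a sulfonyl sulfur. Going by the values given here, no step between two measured compounds is available to guide a forecast for this change. Because compound 3 gives 0.28%, little room is left to fall further, and nothing measured here supports a large rise. The step of a number 0.7 percentage points higher from compound 3 to compound 4 (within the scatter) is expected to stay within the usual scatter. Compound 4 is estimated at 1%, between 0% and 8%.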

Compound 4, percent of the compound remaining: 27%
Compound 4: the middle estimate sits 26 percentage points below what was measured; measured number outside the range, above it.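

In this assay, the group on the sulfonyl sulfur turns out to matter: 3-(trifluoromethyl)phenyl in place of piperidin-1-yl gives a number 26.7 percentage points higher from compound 3 to compound 4 (beyond the scatter). The earlier compounds shown here varied only the core and all stayed very low, whereas this single change at the sulfonyl sulfur lifts the read-out clearly. Nothing measured here explains the rise. On these data alone, whether a plain phenyl ring or a morpholine at this place would give a similar rise stays open. Also open, as far as these compounds go, is whether the same change would help on the cores of compound 1 and compound 2.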